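From bromo to fluoro: the next compound in the series

A few compounds are considered here, and "the series" means these few. Any claim that something is new, unique, unknown or untested is made for them only; others in the source may bear on it.

In a toxicity assay on cells (Macrophage, Mus musculus, strain BALB/c) for cytotoxicity, read by MTT assay (on this read-out higher numbers stand for weaker inhibition and lower numbers for stronger inhibition), compound 1 (`C=CCOc1cc(OC)c(C(=O)/C=C/Cc2ccccc2)c(OCC=C)c1`) gives 14800 nM and compound 2 (`C=CCOc1cc(OC)c(C(=O)/C=C/c2ccccc2Br)c(OCC=C)c1`) gives 5400 nM, the lower of the two numbers. Compound 3 (`C=CCOc1cc(OC)c(C(=O)/C=C/c2ccccc2F)c(OCC=C)c1`) is not yet measured. It carries fluoro in place of bromo on an aromatic carbon. Among the measured compounds shown here, the only measured step, a 2.7-fold lower number from compound 1 to compound 2 (0.44 log units; beyond the scatter), introduced 2-bromophenyl in place of benzyl. It is modest and tests no exchange of one halogen for another, so it bears on this change only loosely. Losing the bromo may give back part of that step, so a smaller move towards a higher number is expected, possibly within the scatter. The expected step is a 1.4-fold higher number from compound 2 to compound 3 (0.14 log units; within the scatter). For compound 3 the estimated value in this assay is 7500 nM, with an expected range from 3000 nM to 18000 nM.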

Compound 3, half-maximal inhibitory concentration: 13300 nM
Compound 3: the middle estimate sits 1.8-fold (0.25 log units) below what was measured; measured number inside the range.
By their numbers in this assay, from the lowest: compound 2; then compounds 3 and 1 (each within the scatter of the next).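

In this assay the halogen on this aromatic carbon, ortho to a large group, is not interchangeable: the exchange of bromo for fluoro gives a 2.5-fold higher number from compound 2 to compound 3 (0.39 log units; beyond the scatter), a step beyond the scatter. With fluoro at this place, the change from benzyl to 2-fluorophenyl gives a 1.1-fold lower number from compound 1 to compound 3 (0.05 log units; within the scatter), within the scatter, so compound 3 cannot be told apart from compound 1 and, among these three compounds, only the 2-bromophenyl compound stands apart. Nothing available explains the difference between the two halogens.

From the compounds shown here alone, whether chloro or iodo at the same carbon would fall nearer to compound 2 or to compound 3 remains open. Also open, going by these compounds, is how a plain phenyl, with hydrogen at this carbon, or an amine there would compare with these halogens.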